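This account rests on a few compounds, and the source may have more. Where it says the series, first, only, none or still open, it means among the compounds named here.

Three compounds of this series share one core. Compound 1 `COc1ccc(Cn2cc[nH]c2=S)cc1` gives 204000 nM in an assay on isolated protein for inhibition of Dopamine beta-hydroxylase (Rattus norvegicus); on this read-out lower numbers stand for stronger inhibition and higher numbers for weaker inhibition. Compound 2 `S=c1[nH]ccn1Cc1ccc(Br)cc1` gives 115000 nM in this assay, the lowest of the three numbers, though compound 1 sits within the scatter of it. Compound 3 `COc1ccc(Cn2cc[nH]c2=S)cc1[N+](=O)[O-]` gives 355000 nM. Compound 4 `O=[N+]([O-])c1ccc(Cn2cc[nH]c2=S)cc1` has not been measured; it differs from compound 2 by nitro in place of bromo on an aromatic carbon. Within the data shown here, two measured steps bear on this change: a 1.8-fold lower number from compound 1 to compound 2 (0.25 log units; within the scatter), and a 1.7-fold higher number from compound 1 to compound 3 (0.24 log units; within the scatter). Among the measured compounds shown here, neither step went beyond the scatter, and no measured pair exchanges nitro for bromo directly. One would therefore expect at most a small step toward a higher number, with a 1.7-fold higher number from compound 2 to compound 4 (0.24 log units; within the scatter). For compound 4 the estimate is 200000 nM, within a range of 80000 nM to 500000 nM.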

Compound 4, half-maximal inhibitory concentration: 52500 nM
The estimate for compound 4 lay 3.8-fold (0.58 log units) above the measured number, outside the stated range (below it).
By their numbers in this assay, from the lowest: compound 4; then compounds 2, 1 and 3 (each within the scatter of the next, the first and the last beyond it).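

In this assay, nitro in place of bromo on this aromatic carbon, para to a group of 7 heavy atoms, gives a 2.2-fold lower number from compound 2 to compound 4 (0.34 log units; beyond the scatter), and nitro in place of methoxy there gives a 3.9-fold lower number from compound 1 to compound 4 (0.59 log units; beyond the scatter). Thus a single exchange at this position can move the number beyond the scatter, which neither earlier step had done. Nothing available here accounts for this result. On these data alone, whether an amine, a carboxylic acid or a nitrile at this position would give a lower or a higher number remains open.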